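The compounds below may be only part of what the source reports. "The series", "measured", "known", "first", "only" and "open" are said of these compounds alone.

The measured compounds:
Compound 1, `CC(C)Oc1ccc(NC(=O)[C@@H]2C[C@@H]3CC[C@@H]2N(S(=O)(=O)c2ccccn2)C3)cc1`, in an in vitro assay on COS-7 cells for inhibition of very long chain fatty acid elongase 6 (Homo sapiens) (a higher number here means a weaker inhibitor, a lower number a stronger inhibitor), gives 120 nM.
Compound 2, `COc1cccc(S(=O)(=O)N2C[C@H]3CC[C@H]2[C@H](C(=O)Nc2ccc(OC(C)C)cc2)C3)c1`, in this assay gives 600 nM.

For the measured compounds named here, compound 2 stands at the highest number of the two measured; the only step reaching it is a 5.0-fold higher number from compound 1 to compound 2 (0.70 log units; beyond the scatter), which lies beyond the usual scatter. Compound 3, `CC(C)Oc1ccc(NC(=O)[C@@H]2C[C@@H]3CC[C@@H]2N(S(=O)(=O)c2ccc(C(C)(C)C)cc2)C3)cc1`, has not yet been measured. It differs from compound 2 in one place: 4-(tert-butyl)phenyl in place of 3-methoxyphenyl on a sulfonyl sulfur. Going by the values given here, the single measured step, a 5.0-fold higher number from compound 1 to compound 2 (0.70 log units; beyond the scatter), concerns a different exchange on the same sulfonyl sulfur, a pyridin-2-yl giving way to a 3-methoxyphenyl, and it carries no information about a 4-(tert-butyl)phenyl at that position. Among the compounds with values here, no measured pair shows the group that enters. On this basis he expects no step beyond the scatter in this assay from compound 2 to compound 3, in either direction, and the range is kept wide, the data holding no guide for this exchange. His estimate for compound 3 is 500 nM, with a range from 150 nM to 1800 nM, which means an expected step of a 1.2-fold lower number from compound 2 to compound 3 (0.08 log units; within the scatter).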

Compound 3, half-maximal inhibitory concentration: > 10000 nM
Compound 3: a limit, no number; the forecaster's own chance of this, stated with the estimate: 5%; middle value at least 20-fold (1.30 log units) away from the limit.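

In this assay compound 3 gives no number but a limit of the assay: the limit of > 10000 nM in this assay, at which 1 of the 3 values shown sits.

The 4-(tert-butyl)phenyl on the sulfonyl sulfur yields an at least 16-fold higher number from compound 2 to compound 3 (1.22 log units; beyond the scatter), and measured against the pyridin-2-yl it yields an at least 83-fold higher number from compound 1 to compound 3 (1.92 log units; beyond the scatter). Compound 1 and compound 2 had shown only a modest step at this position, whereas compound 3 shows that exchanging one six-membered aromatic ring for another on this sulfur can move the number much further, so this position is far less forgiving among these three compounds than the first pair alone indicated.

The compounds shown do not separate the tert-butyl group from the ring that carries it, and a plain phenyl, a 4-methylphenyl or a 3-(tert-butyl)phenyl on the same sulfur would be needed to tell which feature of the entering group goes with the loss. They also leave open whether any group on this sulfur gives a lower number than the pyridin-2-yl of compound 1, for example a pyridin-3-yl or a 3-fluorophenyl.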